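Methoxy on the benzyl group of compound 2: an untested change

This account rests on a few compounds, and the source may have more. Where it says the series, first, only, none or still open, it means among the compounds named here.

Measured compounds and their numbers in this assay:
compound 1, `CCCCCCCCCCCCCC/N=c1\nc(N)c2ncn(Cc3ccccc3)c2c(N)n1` — 4100 nM
compound 2, `CCCCCCCC/N=c1\nc(N)c2ncn(Cc3ccccc3)c2c(N)n1` — 4550 nM

In a functional assay on MCF7 cells (Homo sapiens) for antiproliferative activity, read by WST assay, with a stated time of 72 h (a higher number here means a weaker inhibitor, a lower number a stronger inhibitor), compound 1 gives 4100 nM. Compound 2, which carries hydrogen in place of hexyl on a saturated chain carbon, gives 4550 nM in this assay. Within the data shown here, the single measured step is a 1.1-fold higher number from compound 1 to compound 2 (0.05 log units; within the scatter). Compound 2 thus stands at the highest of the two numbers shown, but its only neighbour, compound 1, sits within the scatter of it, so the two cannot be told apart.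

Compound 3, `CCCCCCCC/N=c1\nc(N)c2ncn(Cc3ccc(OC)cc3)c2c(N)n1`, differs from compound 2 by methoxy in place of hydrogen on an aromatic carbon. Among the measured compounds shown here, the only measured step changes the saturated chain and says nothing about a substituent on the aromatic ring, so no step bears on this change. With no guidance either way, the expectation is a step of no size beyond the scatter, a 1.1-fold lower number from compound 2 to compound 3 (0.03 log units; within the scatter). Compound 3 is therefore estimated to give 4200 nM in this assay, with a range from 1500 nM to 12000 nM in which this estimate is expected to fall.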

Compound 3, half-maximal inhibitory concentration: 3800 nM
For compound 3 the middle estimate is 1.1-fold (0.04 log units) above the measured one; measured number inside the range.
By their numbers in this assay, from the lowest: compounds 3, 1 and 2 (each within the scatter of the next).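

In this assay, methoxy in place of hydrogen on an aromatic carbon, para to a large group, gives a 1.2-fold lower number from compound 2 to compound 3 (0.08 log units; within the scatter) and so produces no change that can be told from the scatter. Among these compounds, the earlier step concerned only the saturated chain, so this is the first reading from the benzyl ring, and it shows that going from benzyl to 4-methoxybenzyl leaves compound 3 indistinguishable from compound 2 in this measurement. No supporting evidence bears on why the number stays within the scatter.

The compounds shown leave open whether another group at this same place, such as an amine, a carboxylic acid or a longer chain ending in an ether oxygen, would move the number beyond the scatter. They also leave open whether methoxy on a different carbon of the ring, or 4-methoxybenzyl combined with the longer chain of compound 1, would likewise stay within the scatter.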